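A few compounds are considered here, and "the series" means these few. Any claim that something is new, unique, unknown or untested is made for them only; others in the source may bear on it.

Compound 1 `O=C(Nc1cccc(-n2cc(-c3ccncc3)c(-c3ccc(Cl)c(O)c3)n2)c1)Nc1cccc(C(F)(F)F)c1`: > 32500 nM
Compound 2 `COc1cc(-c2nn(-c3cccc(NC(=O)Nc4cc(C(F)(F)F)cc(C(F)(F)F)c4)c3)cc2-c2ccncc2)ccc1Cl`: > 50000 nM

Both measured compounds were tested in a functional assay on CCRF-CEM cells (Homo sapiens) for inhibition, read by sulforhodamine B assay, with a stated time of 48 h (a higher number here means that more compound is tolerated, a lower number that less compound is tolerated), and neither gave a number. For compound 2 the result is a limit, (the limit of > 50000 nM in this assay, at which 1 of the 2 values shown sits), so its place on the scale is known only as the side it lies on. Compound 1 likewise ends at a limit, (the limit of > 32500 nM in this assay, at which 1 of the 2 values shown sits). Among the compounds with values here, no two measured compounds differ in just one place, so there is no measured step to lean on.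

Compound 3 `O=C(Nc1cccc(-n2cc(-c3ccncc3)c(-c3ccc(Cl)c(O)c3)n2)c1)Nc1cc(C(F)(F)F)cc(C(F)(F)F)c1` is the unmeasured member. It differs from compound 2 by hydrogen in place of methyl on an oxygen on an aromatic ring; read one bond further out, the change is methoxy to hydroxy, 4-chloro-3-methoxyphenyl to 4-chloro-3-hydroxyphenyl.

With both measured compounds at limits, no shift beyond the scatter is expected, and the step from compound 2 to compound 3 is estimated as a number no higher from compound 2 to compound 3 (the limit leaves the size open) in this assay. Compound 3 is therefore expected to give 50000 nM in this assay, within 20000 nM to 120000 nM, most probably again as a limit rather than a number.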

Compound 3, concentration lethal to 50% of the cells: > 50000 nM
Compound 3: no number, only a limit (the forecaster's own chance of this, stated with the estimate: 80%); the middle value sits exactly at the limit.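

In this assay compound 3 ends at a limit, as do compound 1 and compound 2, so the steps to compound 3 from compound 1 and from compound 2 cannot be read: the limit of > 50000 nM in this assay, at which 2 of the 3 values shown sit.

The compounds shown leave open where any of the three lies on the scale, and whether hydroxy for methoxy or trifluoromethyl for hydrogen changes the read-out at all.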